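This account rests on a few compounds, and the source may have more. Where it says the series, first, only, none or still open, it means among the compounds named here.

Measured compounds in a functional assay on BT-474 cells (Homo sapiens) for antiproliferative activity, read by MTT assay, with a stated time of 72 h; on this read-out higher numbers stand for weaker inhibition and lower numbers for stronger inhibition:

Compound 1, `CC(Nc1nc(N)nc2ccc(-c3cnn(C4CCNCC4)c3)cc12)c1c(Cl)ccc(F)c1Cl`: compound 1 gives 5100 nM
Compound 2, `CC(Oc1ncnc2ccc(-c3cnn(C4CCNCC4)c3)cc12)c1c(Cl)ccc(F)c1Cl`: compound 2 gives 4140 nM
Compound 3, `CC(Nc1nc(N)nc2ccc(-c3cnn(C)c3)cc12)c1c(Cl)ccc(F)c1Cl`: compound 3 gives 7120 nM

All three numbers lie within the usual scatter of one another, so no ordering among them is claimed. Compound 1 and compound 3 share a core and differ by one change: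

methyl in place of piperidin-4-yl on an aromatic nitrogen

This change gave a 1.4-fold higher number from compound 1 to compound 3 (0.14 log units; within the scatter) in this assay.

Compound 2 carries a different core from compound 1; the difference between the two cores is not broken down here, and only the two values themselves, which lie within the scatter of each other, are available for comparison.

The unmeasured compound 4, `CC(Oc1ncnc2ccc(-c3cnn(C)c3)cc12)c1c(Cl)ccc(F)c1Cl`, stands to compound 2 as compound 3 stands to compound 1:

methyl in place of piperidin-4-yl on an aromatic nitrogen

The place lines of the two changes agree word for word, so this is the same change on the second core. For compound 4 the expected step is a 1.4-fold higher number from compound 2 to compound 4 (0.15 log units; within the scatter), a flat outcome, because the same change gave a 1.4-fold higher number from compound 1 to compound 3 (0.14 log units; within the scatter) from compound 1 to compound 3, and nothing in the data separates the two cores in their response to it. Compound 4 is therefore estimated at 5800 nM in this assay, with a range of 2500 nM to 13000 nM.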

Compound 4, half-maximal inhibitory concentration: 45600 nM
Beside the measured number, compound 4's estimate is 7.9-fold (0.90 log units) below it; measured number outside the range, above it.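

In this assay, methyl in place of piperidin-4-yl on an aromatic nitrogen gave an 11-fold higher number from compound 2 to compound 4 (1.04 log units; beyond the scatter). On the two cores shown, this change therefore does not carry over with the same size: the same change on two cores in this assay, a 1.4-fold higher number (0.14 log units; within the scatter) from compound 1 to compound 3 and an 11-fold higher number (1.04 log units; beyond the scatter) from compound 2 to compound 4, 7.9-fold (0.90 log units) apart, beyond the scatter of two such steps

The result shows that the size of the step on the core of compound 1 is a poor guide to its size on the core of compound 2, but it rests on one pair per core and gives neither a cause nor a rule for any further core.

The compounds shown leave open which part of piperidin-4-yl accounts for the step on the core of compound 2; cyclohexyl, which lacks the ring nitrogen, or a short chain ending in an amine on the same aromatic nitrogen would help separate ring from amine. Also open, going by these compounds, is how the same change behaves on a core carrying only part of the difference between the core of compound 1 and the core of compound 2.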